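This account rests on a few compounds, and the source may have more. Where it says the series, first, only, none or still open, it means among the compounds named here.

Compound 1, `COc1cc(/C=C2\CCC/C(=C\c3ccccc3[N+](=O)[O-])C2=O)cc(OC)c1OC`, in a physicochemical assay for lipophilicity (on this read-out higher numbers stand for higher lipophilicity and lower numbers for lower lipophilicity), gives 4.86. Compound 2, `Cc1ccc(/C=C2\CCC/C(=C\c3cccc([N+](=O)[O-])c3)C2=O)cc1`, in this assay gives 5.06. Compound 3, `COc1ccc(/C=C2\CCC/C(=C\c3ccccc3[N+](=O)[O-])C2=O)cc1`, in this assay gives 4.86.

Compound 3 shows the same number as compound 1 at the digits shown, and compound 2 differs from both of them only within the usual scatter, so the three measured numbers sit close together. Compound 4, `O=C1/C(=C/c2ccccc2)CCC/C1=C\c1ccccc1[N+](=O)[O-]`, has not been measured yet. The change from compound 3 to compound 4 is hydrogen in place of methoxy on an aromatic carbon. Going by the values given here, no comparable pair among the measured compounds shows what such a change does here, so the expected step is one that stays within the scatter, with no clear direction. The expected step in this assay from compound 3 to compound 4 is a number 0.01 log units lower from compound 3 to compound 4 (within the scatter). Compound 4 is therefore estimated at 4.85, within 4.55 to 5.15.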

Compound 4, partition coefficient: 4.86
Compound 4: the middle estimate sits 0.01 log units below what was measured; the measured number falls inside the stated range.
By their numbers in this assay, from the lowest: compounds 1, 3, 4 and 2 (each within the scatter of the next).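

This is the only pair shown that differs in one place, so it gives the one direct reading of the 4-methoxyphenyl to phenyl change. In this assay, going by these compounds alone, hydrogen in place of methoxy gives no change at the digits printed from compound 3 to compound 4 (within the scatter) and so, at this position on this core, removing methoxy produces no visible step. Nothing at hand explains this result.

The compounds shown leave open whether an amine or a carboxylic acid on the same aromatic carbon would also leave the number unchanged. They also leave open whether this change reads the same on other compounds.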